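A few compounds are considered here, and "the series" means these few. Any claim that something is new, unique, unknown or untested is made for them only; others in the source may bear on it.

Measured compounds:
compound 1 `COC1(c2csc(Sc3ccc4c(c3)OCC/C4=N\OCC#N)c2)CCOCC1`, 60 nM in a functional assay (blood) for inhibition, with Homo sapiens as the target; a lower number here means a stronger inhibitor, a higher number a weaker inhibitor
compound 2 `CO[C@]1(c2cnc(S(=O)(=O)c3ccc(/C(C)=N/O)cc3)s2)CCO[C@@H](C)C1`, 320 nM
compound 3 `COC1(c2csc(Sc3ccc4c(c3)OCC/C4=N\O)c2)CCOCC1`, 40 nM

Compound 3 is the parent of compound 1 within the first core; the change is cyanomethyl in place of hydrogen on an oxygen and it gave a 1.5-fold higher number from compound 3 to compound 1 (0.18 log units; within the scatter). Compound 2 carries a different core; the difference between the two cores is not broken down here, and compound 2 shows the highest of the three numbers, with compound 3 and compound 1 both well below it in this assay.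

Compound 4 `CO[C@]1(c2cnc(S(=O)(=O)c3ccc(/C(C)=N/OCC#N)cc3)s2)CCO[C@@H](C)C1` has not yet been measured. It relates to compound 2 by cyanomethyl in place of hydrogen on an oxygen, the same change as from compound 3 to compound 1. Resting on compound 2 at 320 nM and on the step of a 1.5-fold higher number from compound 3 to compound 1 (0.18 log units; within the scatter), the expected step is a 1.4-fold higher number from compound 2 to compound 4 (0.15 log units; within the scatter). Compound 4 is therefore estimated at 450 nM, within 170 nM to 1200 nM.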

Compound 4, half-maximal inhibitory concentration in the Homo sapiens assay: 140 nM
The estimate for compound 4 lay 3.2-fold (0.51 log units) above the measured number; measured number outside the range, below it.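

In the Homo sapiens assay, cyanomethyl in place of hydrogen on an oxygen gave a 2.3-fold lower number from compound 2 to compound 4 (0.36 log units; beyond the scatter), so on these two cores the change does not carry over with one direction or size: the same change on two cores in the Homo sapiens assay, a 1.5-fold higher number (0.18 log units; within the scatter) from compound 3 to compound 1 and a 2.3-fold lower number (0.36 log units; beyond the scatter) from compound 2 to compound 4, 3.4-fold (0.54 log units) apart, beyond the scatter of two such steps. On the core of compound 2, the same change also lowers the number in a physicochemical assay for solubility; on this read-out lower numbers stand for lower solubility and higher numbers for higher solubility: the measured solubility of compound 2, 31000 nM, and of compound 4, 1000 nM, a 31-fold lower number (1.49 log units; beyond the scatter). In the physicochemical assay compound 2 gives 31000 nM and compound 4 gives 1000 nM. These two pairs show that the step differs between these cores, but they do not show which part of the core accounts for the difference or how the change would read on any further core.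

Open, from the compounds shown here alone, is whether methyl or a longer chain ending in an amine, in place of cyanomethyl on that oxygen, would keep the lower number in the Homo sapiens assay on the core of compound 2 with a smaller loss in the physicochemical assay.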